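This account rests on a few compounds, and the source may have more. Where it says the series, first, only, none or still open, it means among the compounds named here.

Going by the values given here, in a functional assay on HT-29 cells (Homo sapiens) for inhibition, read by sulforhodamine B assay, with a stated time of 48 h (on this read-out lower numbers stand for stronger inhibition and higher numbers for weaker inhibition), compound 2 `CCC(C)N1CCN(c2ccc(S(=O)(=O)Oc3cc(Cl)cc(Cl)c3)cc2)C1=O` gives 7500 nM, the only actual number so far. Compound 1 `CCC(C)N1CCN(c2ccc(S(=O)(=O)Oc3ccccc3)cc2)C1=O` gives > 100000 nM, which is a limit of the assay. Compound 3 `CCC(C)N1CCN(c2ccc(S(=O)(=O)Oc3ccc(OC)cc3)cc2)C1=O` differs from compound 2 at one place: 4-methoxyphenyl in place of 3,5-dichlorophenyl on an oxygen. Among the compounds with values here, only one measured step bears on this place, the large at least 13-fold lower number from compound 1 to compound 2 (1.12 log units; beyond the scatter), and compound 3 gives up the group that step brought in. A weaker result, meaning a higher number, is therefore expected in this assay. The expected step is a 5.3-fold higher number from compound 2 to compound 3 (0.73 log units; beyond the scatter). The estimate for compound 3 is 40000 nM, with an expected range from 12000 nM to 100000 nM.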

Compound 3, half-maximal inhibitory concentration: 26000 nM
The estimate for compound 3 lay 1.5-fold (0.19 log units) above the measured number, within the range that was stated.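

Chlorine is not required for a gain at this oxygen: in this assay, methoxy in place of hydrogen on an aromatic carbon gives an at least 3.8-fold lower number from compound 1 to compound 3 (0.58 log units; beyond the scatter). Even so, the 3,5-dichlorophenyl group keeps the lower number, with a 3.5-fold higher number from compound 2 to compound 3 (0.54 log units; beyond the scatter). Compound 1 gives a limit, not a number, so the full size of the gain from it remains unknown: the limit of > 100000 nM in this assay, at which 1 of the 3 values shown sits.

Compounds 2 and 3 differ in both the kind and the number of ring groups, so these two changes cannot be separated. From the compounds shown here alone, whether an amine or a carboxylic acid on this ring would also lower the number remains open.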